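Swapping Bromo for Chloro on the Shared Core

A few compounds are considered here, and "the series" means these few. Any claim that something is new, unique, unknown or untested is made for them only; others in the source may bear on it.

Compound 2 `Cc1ccc([N+](=O)[O-])cc1S(=O)(=O)N(C)/N=C/c1cnn2ccc(Br)cc12` is one of two compounds tested in an assay on isolated protein for inhibition of phosphatidylinositol 4,5-bisphosphate 3-kinase catalytic subunit beta isoform (Homo sapiens), read by 33P incorporation, with a stated time of 60 min (on this read-out higher numbers stand for weaker inhibition and lower numbers for stronger inhibition), and in this assay compound 2 gives 230 nM, the only full number shown. Compound 1 `CC(=O)Oc1ccn2ncc(/C=N/N(C)S(=O)(=O)c3cc([N+](=O)[O-])ccc3C)c2c1` gives only a limit of the assay, > 1000 nM, which is the limit of > 1000 nM in this assay, at which 1 of the 2 values shown sits. For the measured compounds named here, the single measured step, an at least 4.3-fold lower number from compound 1 to compound 2 (0.63 log units; beyond the scatter), is the only change with a number attached and concerns a different substituent than the one now in question. Compound 3 `Cc1ccc([N+](=O)[O-])cc1S(=O)(=O)N(C)/N=C/c1cnn2ccc(Cl)cc12` differs from compound 2 by chloro in place of bromo on an aromatic carbon. Going by the values given here, no measured step bears directly on a bromo-to-chloro exchange; the one step known replaced acetoxy by bromo and was at least modest. Without a measured halogen swap, compound 3 is expected to stay close to compound 2, a step of a 1.3-fold higher number from compound 2 to compound 3 (0.12 log units; within the scatter) in this assay, within the usual scatter. Compound 3 is estimated at 300 nM, with a range from 120 nM to 800 nM.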

Compound 3, half-maximal inhibitory concentration: 390 nM
The estimate for compound 3 lay 1.3-fold (0.11 log units) below the measured number, within the range that was stated.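

In this assay, chloro in place of bromo on this aromatic carbon gives a 1.7-fold higher number from compound 2 to compound 3 (0.23 log units; within the scatter), so the two halogens cannot be told apart on this read-out. Chloro in place of acetoxy gives an at least 2.5-fold lower number from compound 1 to compound 3 (0.40 log units; beyond the scatter), which shows that the step away from acetoxy seen with bromo is repeated with a second halogen. The figure for compound 1 in this comparison is a limit of the assay and not a number: the limit of > 1000 nM in this assay, at which 1 of the 3 values shown sits.

The compounds shown leave open how a methoxy group, an amine or a carboxylic acid on this aromatic carbon would read, and whether fluoro or iodo would stay with chloro and bromo. They also leave open whether the halogens would remain indistinguishable if the nitro group on the other ring were replaced.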